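The compounds below may be only part of what the source reports. "The series", "measured", "known", "first", "only" and "open" are said of these compounds alone.

Of the compounds shown here, three that share one core have been measured in a functional assay on OVCAR-3 cells (Homo sapiens) for antiproliferative activity, read by sulforhodamine B assay, with a stated time of 72 h; a higher number here means a weaker inhibitor, a lower number a stronger inhibitor. Compound 1 `O=S(=O)(Nc1ccccn1)c1ccc(Nc2nncc3ccccc23)cc1` gives 83 nM. Compound 2 `Cc1cc(C)nc(NS(=O)(=O)c2ccc(Nc3nncc4ccccc34)cc2)n1` gives 3.4 nM, and compound 3 `NS(=O)(=O)c1ccc(Nc2nncc3ccccc23)cc1` gives 14 nM. Among these three numbers compound 3 stands second highest: its nearest neighbour is compound 2, separated by a 4.1-fold higher number from compound 2 to compound 3 (0.61 log units; beyond the scatter), and the furthest is compound 1, separated by a 5.9-fold lower number from compound 1 to compound 3 (0.77 log units; beyond the scatter). Every measured step changes only the group on the sulfonamide nitrogen, and those steps ranged from modest, as in a 5.9-fold lower number from compound 1 to compound 3 (0.77 log units; beyond the scatter), to large, as in a 24-fold lower number from compound 1 to compound 2 (1.39 log units; beyond the scatter). Compound 4 `N#Cc1ccc(Nc2nncc3ccccc23)cc1` brings a change of a different kind: cyano in place of sulfamoyl on an aromatic carbon. Among the compounds with values here, no measured pair exchanges the sulfamoyl group itself, so none of the measured steps bears directly on this one; they show only that changes at this end of the molecule can move the number well beyond the scatter, in either direction. With that in mind, compound 4 is expected to give 50 nM, with a range from 8 nM to 300 nM. The expected step is a 3.6-fold higher number from compound 3 to compound 4 (0.55 log units; beyond the scatter), an estimate of a somewhat weaker inhibitor that carries wide uncertainty.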

Compound 4, half-maximal inhibitory concentration: 4.3 nM
Beside the measured number, compound 4's estimate is 12-fold (1.07 log units) above it; the whole stated range lies above it.
By their numbers in this assay, from the lowest: compounds 2 and 4 (each within the scatter of the next); then compound 3; then compound 1.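

In this assay, the sulfamoyl group can be swapped outright, not only altered on its nitrogen: cyano in its place gives a 3.3-fold lower number from compound 3 to compound 4 (0.51 log units; beyond the scatter), a modest step beyond the scatter. Compounds 1, 2 and 3 all kept the sulfonyl unit and varied only what sat on the sulfonamide nitrogen, so they could not show whether the number depended on that unit; compound 4 has no sulfur, no hydrogen-bond donor in the entering group, and 2 heavy atoms where sulfamoyl has 4, yet its number is lower than that of compound 3. For this one pair, then, the sulfamoyl group is not needed for a single-digit nanomolar result on this core, and nothing available here explains why the number drops with this change.

This single swap alters the atoms, the donor and the acceptors all at once, so the compounds shown cannot tell which of these differences matters. Going by these compounds, what a carboxylic acid, an amine or a primary amide would give on the same aromatic carbon also stays open.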